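The source may report more compounds than this note shows. Statements on the series, on what has been measured and on what is new or still open speak of the compounds shown alone.

All values below come from a functional assay on CCRF-CEM cells (Homo sapiens) for cytotoxicity, read by cell counting, with a stated time of 3 days; a higher number here means a weaker inhibitor, a lower number a stronger inhibitor.

compound 1, `C=C(Br)C(=O)Nc1cccc(/C=C2\SC(=O)N(Cc3ccc(C(F)(F)F)cc3)C2=O)c1`: 920 nM
compound 2, `C=C(Br)C(=O)Nc1cccc(/C=C2\SC(=O)N(Cc3ccc(Cl)cc3)C2=O)c1`: 1400 nM
compound 3, `Nc1cccc(/C=C2\SC(=O)N(Cc3ccc(C(F)(F)F)cc3)C2=O)c1`: > 250000 nM

The value of compound 3 is a limit of the assay and not a number.

Compound 1 and compound 2 share the core of compound 1 and differ only in chloro in place of trifluoromethyl on an aromatic carbon; the step is a 1.5-fold higher number from compound 1 to compound 2 (0.18 log units; within the scatter). Compound 3 differs from compound 1 in hydrogen in place of (1-bromoethenyl)carbonyl on a nitrogen on an aromatic ring; this step is an at least 270-fold higher number from compound 1 to compound 3 (2.43 log units; beyond the scatter), with compound 3 at the limit of > 250000 nM in this assay, at which 1 of the 3 values shown sits.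

Compound 4, `Nc1cccc(/C=C2\SC(=O)N(Cc3ccc(Cl)cc3)C2=O)c1`, remains to be measured in this assay. It differs from compound 3 in chloro in place of trifluoromethyl on an aromatic carbon, the same change, at the same place, as from compound 1 to compound 2.

Compound 4 is expected to give 250000 nM, most likely again only as a limit. The step expected here, a number no higher from compound 3 to compound 4 (the limit leaves the size open), rests on the earlier step being within the scatter, because a 1.5-fold higher number from compound 1 to compound 2 (0.18 log units; within the scatter), and on compound 3 sitting at the limit of > 250000 nM in this assay, at which 1 of the 3 values shown sits. Should a number be obtained for compound 4, it is expected between 100000 nM and 1000000 nM.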

Compound 4, half-maximal inhibitory concentration: > 250000 nM
Compound 4: no number, only a limit (the forecaster's own chance of this, stated with the estimate: 85%); the middle value lies on the limit itself.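

In this assay, hydrogen in place of (1-bromoethenyl)carbonyl on the nitrogen gives an at least 170-fold higher number from compound 2 to compound 4 (2.25 log units; beyond the scatter) on the core carrying chloro, so the large step seen on the core carrying trifluoromethyl is found again on the second core: the same change on two cores in this assay, an at least 270-fold higher number (2.43 log units; beyond the scatter) from compound 1 to compound 3 and an at least 170-fold higher number (2.25 log units; beyond the scatter) from compound 2 to compound 4; the limit leaves it open whether they differ. Among these compounds, both steps end on a limit of the assay, so they show only that each step is large, not that the two are equal in size or how large either one is: the limit of > 250000 nM in this assay, at which 2 of the 4 values shown sit. The step between the two compounds without the (1-bromoethenyl)carbonyl group cannot be read, so the change from trifluoromethyl to chloro can be compared only through a 1.5-fold higher number from compound 1 to compound 2 (0.18 log units; within the scatter), which lies within the scatter.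

It remains open how much of the large step depends on the bromine, as neither an acryloyl nor an acetyl group on that nitrogen stands among the compounds shown. Also open, from the compounds shown here alone, is how groups other than trifluoromethyl and chloro, such as methoxy or a nitrile, behave on that aromatic carbon.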